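Chloro to Bromo on the Phenyl Ring

The compounds below may be only part of what the source reports. "The series", "measured", "known", "first", "only" and "open" are said of these compounds alone.

Compound 1 `c1ccc(-c2cn3ccnc3c(-c3ccc4ncn(C5CCCCC5)c4c3)n2)cc1` is the parent of this small set. In a functional assay on OVCAR-5 cells (Homo sapiens) for inhibition, read by sulforhodamine B assay, with a stated time of 48 h, tested at 10 uM (on this read-out lower numbers stand for less inhibition and higher numbers for more inhibition at the one concentration tested (going by the name of the read-out)), compound 1 gives 7.87%. Compound 2 `Clc1ccc(-c2cn3ccnc3c(-c3ccc4ncn(C5CCCCC5)c4c3)n2)cc1` carries chloro in place of hydrogen on an aromatic carbon, and in this assay compound 2 gives 0.84%; the step of a number 7 percentage points lower from compound 1 to compound 2 (within the scatter) is within the scatter. On the numbers shown, compound 2 stands lowest of the two, with compound 1 as its only neighbour, the step between them being within the scatter.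

Compound 3 `Brc1ccc(-c2cn3ccnc3c(-c3ccc4ncn(C5CCCCC5)c4c3)n2)cc1` differs from compound 2 by one change: bromo in place of chloro on an aromatic carbon. Among the measured compounds shown here, the only measured step that bears on it is the one from compound 1 to compound 2, where adding chloro at this place moved the inhibition by a number 7 percentage points lower from compound 1 to compound 2 (within the scatter), a change within the scatter. For the measured compounds named here, no measured step exchanges one halogen for another, so nothing here suggests a shift beyond the scatter. The step from compound 2 to compound 3 is therefore expected to be small, a number 2.2 percentage points higher from compound 2 to compound 3 (within the scatter). Compound 3 is estimated at 3%, with a range from -8% to 15%.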

Compound 3, a percentage reported as inhibition, at one concentration (the size of the read-out at that concentration, not a potency): 8.95%
Beside the measured number, compound 3's estimate is 6 percentage points below it; low and high end bracket the measured number.
By their numbers in this assay, from the lowest: compounds 2, 1 and 3 (each within the scatter of the next).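

The bromo compound adds a second halogen at this place, on an aromatic carbon para to a large group, and in this assay the exchange of one halogen for the other gives a number 8.1 percentage points higher from compound 2 to compound 3 (within the scatter) and the replacement of hydrogen by bromo gives a number 1.1 percentage points higher from compound 1 to compound 3 (within the scatter). Read with the earlier step, a number 7 percentage points lower from compound 1 to compound 2 (within the scatter), this means that hydrogen, chloro and bromo at this place have now been compared with one another, and no pair of them differs by more than the usual scatter, so this read-out at its one concentration does not separate these three compounds. Nothing available here offers an explanation for these small steps.

Going by these compounds, what a group of another kind at this place would do, such as an amine, a carboxylic acid or a longer chain, stays open, as does whether any of them would give a step beyond the scatter. Also open, on these data alone, is how these compounds would compare at other concentrations, since a single-concentration percentage is not a measure of potency.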